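Swapping Methoxy for Nitro: A Cytotoxicity Limit Expected

The source may report more compounds than this note shows. Statements on the series, on what has been measured and on what is new or still open speak of the compounds shown alone.

Three close relatives of one shared core have been tested in an ADME assay on HepG2 cells (Homo sapiens) for cytotoxicity, read by luminescence, with a stated time of 72 h; on this read-out lower numbers stand for an effect already at smaller amounts and higher numbers for an effect only at larger amounts of compound. Compound 1 `C=Cc1cccc(-c2[nH]c3cc(OC)ccc3c(=O)c2C(=O)OCC)c1` carries a vinyl group on its outer aromatic ring. In this assay compound 1 gives > 21500 nM, which is a limit of the assay and not a number. Compound 2 `CCOC(=O)c1c(-c2cccc(OC)c2)[nH]c2cc(OC)ccc2c1=O` carries a methoxy group instead. In this assay compound 2 gives > 21500 nM, again only a limit, so compound 2 stands at the same limit as every other value shown. Compound 3 `CCOC(=O)c1c(-c2cccc(S(C)(=O)=O)c2)[nH]c2cc(OC)ccc2c1=O` carries a methylsulfonyl group. In this assay compound 3 gives > 21500 nM, also a limit. Because all three sit at the limit of > 21500 nM in this assay, at which 3 of the 3 values shown sit, the steps a step that the two limits leave unreadable from compound 1 to compound 2, a step that the two limits leave unreadable from compound 1 to compound 3 and a step that the two limits leave unreadable from compound 2 to compound 3 have no readable size. Compound 4 `CCOC(=O)c1c(-c2cccc([N+](=O)[O-])c2)[nH]c2cc(OC)ccc2c1=O` has not been measured; it differs from compound 2 by nitro in place of methoxy on an aromatic carbon. Going by the values given here, no measured step gives a size or direction to lean on, so the result for the new change is expected to remain at the same limit. For compound 4 the expected value is 30000 nM, within a range from 15000 nM to 100000 nM. The step expected in this assay, a step that the limit leaves unreadable from compound 2 to compound 4, is essentially none.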

Compound 4, half-maximal effective concentration: > 21500 nM
Compound 4: only a limit was reported; the forecaster's own chance of this, stated with the estimate: 85%; the middle value does not contradict the limit.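

Going by these compounds alone, compound 4 sits at a limit of the assay, as do compound 1, compound 2 and compound 3, so no step between compound 4 and any of them can be read: the limit of > 21500 nM in this assay, at which 4 of the 4 values shown sit.

The compounds shown leave open whether the vinyl, methoxy, methylsulfonyl and nitro groups differ at all in this assay at higher concentrations.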